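Carboxy to chloro on compound 3

A few compounds are considered here, and "the series" means these few. Any claim that something is new, unique, unknown or untested is made for them only; others in the source may bear on it.

In a functional assay on DU-145 cells (Homo sapiens) for inhibition, read by trypan blue exclusion, with a stated time of 96 h (on this read-out lower numbers stand for stronger inhibition of growth and higher numbers for weaker inhibition of growth), the values so far are:
compound 1 `COc1ccccc1/C=C(/SCc1ccc(F)cc1)C(=O)c1ccc(Cl)cc1` gives 10000 nM
compound 2 `Cc1ccc(S(=O)(=O)/C(=C/c2ccc(N(C)C)cc2)C(=O)c2ccc(Cl)cc2)cc1` gives > 100000 nM
compound 3 `CN(C)c1ccc(/C=C(/SCc2ccc(F)cc2)C(=O)c2ccc(C(=O)O)cc2)cc1` gives 10000 nM

Compound 3 at 10000 nM stands level with compound 1 at the digits shown, within the scatter. Compound 2, which carries the 4-chlorophenyl group, reads > 100000 nM and this is a limit of the assay, not a number.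

Compound 4 `CN(C)c1ccc(/C=C(/SCc2ccc(F)cc2)C(=O)c2ccc(Cl)cc2)cc1` is still unmeasured. The change chloro in place of carboxy on an aromatic carbon puts chloro in place of carboxy on an aromatic carbon, para to a large group. Going by the values given here, no measured pair isolates this change. Compound 1 also carries the 4-chlorophenyl group and gives 10000 nM so only a modest step is expected, toward stronger inhibition of growth. The estimated step runs a 2.5-fold lower number from compound 3 to compound 4 (0.40 log units; beyond the scatter) and could still prove to lie within the scatter. In this assay the estimate for compound 4 is 4000 nM with a range from 500 nM to 20000 nM as expected bounds.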

Compound 4, concentration for 50% growth inhibition: 50000 nM
Compound 4: middle estimate off by 13-fold (1.10 log units), on the low side, outside the stated range (above it).
By their numbers in this assay, from the lowest: compounds 1 and 3 (each within the scatter of the next); then compound 4. At a limit, above all of these: compound 2.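

In this assay, chloro in place of carboxy on an aromatic carbon, para to a large group, gives a 5.0-fold higher number from compound 3 to compound 4 (0.70 log units; beyond the scatter), so at this position the carboxy group reads better than chloro on this core. The 4-chlorophenyl group does not set the level by itself: with that group kept, 4-(dimethylamino)phenyl in place of 2-methoxyphenyl gives a 5.0-fold higher number from compound 1 to compound 4 (0.70 log units; beyond the scatter). (4-Fluorobenzyl)sulfanyl in place of (4-methylphenyl)sulfonyl gives an at least 2.0-fold lower number from compound 2 to compound 4 (0.30 log units; that floor lies within the scatter), a step that rests on a limit and not on a number: the limit of > 100000 nM in this assay, at which 1 of the 4 values shown sits.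

The compounds shown leave open whether carboxy holds the same advantage over chloro with the 2-methoxyphenyl group in place. They also leave open whether that advantage needs the free carboxylic acid, which a methyl ester or a primary amide at this position would test.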